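Compound 3 loses its (pyrrolidin-1-yl)methyl group

The source may report more compounds than this note shows. Statements on the series, on what has been measured and on what is new or still open speak of the compounds shown alone.

Measured so far in an in vitro ADME assay on microsomes from liver (Homo sapiens) for pharmacokinetics (on this read-out lower numbers stand for slow clearance and higher numbers for fast clearance), the series reads as follows.
Compound 1 `Cc1ccc(S(=O)(=O)N2C=CNC(=O)[C@H]2CC(=O)N[C@@H]2CCCc3cc(CN4CCCCC4)ccc32)cc1` gives < 50 mL.min-1.g-1 as a limit.
Compound 2 `Cc1ccc(S(=O)(=O)N2C=CNC(=O)[C@H]2CC(=O)N[C@@H]2CCCc3cc(CN(C)C)ccc32)cc1` gives < 50 mL.min-1.g-1 as a limit.
Compound 3 `Cc1ccc(S(=O)(=O)N2C=CNC(=O)[C@H]2CC(=O)N[C@@H]2CCCc3cc(CN4CCCC4)ccc32)cc1` gives < 50 mL.min-1.g-1 as a limit.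

Compound 3 therefore has no exact number in this assay and shares its position with the other two compounds, as the series offers only the limit of < 50 mL.min-1.g-1 in this assay, at which 3 of the 3 values shown sit, and nothing finer. Compound 4 `Cc1ccc(S(=O)(=O)N2C=CNC(=O)[C@H]2CC(=O)N[C@@H]2CCCc3ccccc32)cc1` differs from compound 3 by hydrogen in place of (pyrrolidin-1-yl)methyl on an aromatic carbon and so carries no group at that aromatic carbon beyond the hydrogen. The measured steps bear on this only in part, as each replaces one group on the saturated chain carbon with another. They are a step that the two limits leave unreadable from compound 1 to compound 2 and a step that the two limits leave unreadable from compound 1 to compound 3 and also a step that the two limits leave unreadable from compound 2 to compound 3 in this series. Among the compounds with values here, no measured step removes the group entirely. With no readable size to carry over, no change beyond the scatter is expected, and the estimated step is a step that the limit leaves unreadable from compound 3 to compound 4 in this assay without a firm direction. For compound 4 the estimate is 35 mL.min-1.g-1 as the expected value, with an expected range from 12 mL.min-1.g-1 to 100 mL.min-1.g-1 in this read-out.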

Compound 4, intrinsic clearance in microsomes: 514 mL.min-1.g-1
Compound 4: middle estimate off by 15-fold (1.17 log units), on the low side; the whole stated range lies below it.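

In this assay, within the data shown here, the earlier compounds varied only the amine on the chain carbon, and the steps among them cannot be read, as all three values are limits: the limit of < 50 mL.min-1.g-1 in this assay, at which 3 of the 4 values shown sit. Replacing the whole group with hydrogen on the aromatic carbon gives an at least 10-fold higher number from compound 3 to compound 4 (1.01 log units; beyond the scatter), and the matching replacements give an at least 10-fold higher number from compound 2 to compound 4 (1.01 log units; beyond the scatter) and an at least 10-fold higher number from compound 1 to compound 4 (1.01 log units; beyond the scatter). At this position, each of the three amine-bearing groups therefore goes with a value at the limit, while hydrogen in compound 4 goes with a far higher number.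

The compounds shown leave open whether the amine nitrogen matters or whether any group at this aromatic carbon would do, which a plain methyl, a hydroxymethyl or a carboxylic acid there could separate. They also leave open how the three amines rank in this assay.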